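This account rests on a few compounds, and the source may have more. Where it says the series, first, only, none or still open, it means among the compounds named here.

Measured compounds:
Compound 1 `CC(C)n1ncc2c(C(=O)Nc3c(F)cccc3F)cc(-c3cccs3)nc21` gives > 200000 nM in an ADME assay on LLC-MK2 cells (Macaca mulatta) for cytotoxicity, read by spectrophotometry and crystal violet staining, with a stated time of 4 days (on this read-out higher numbers stand for lower toxicity in this test and lower numbers for higher toxicity in this test), a limit of the assay rather than a number.
Compound 2 `CC(C)n1ccc2c(C(=O)Nc3ccccn3)cc(-c3cccs3)nc21` gives > 200000 nM in this assay, again a limit.
Compound 3 `CC(C)n1ncc2c(C(=O)Nc3ccccc3F)cc(-c3ccccn3)nc21` gives 100000 nM in this assay.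

Compound 1 thus stands at a limit, not a number; it shares this position with the limit of > 200000 nM in this assay, at which 2 of the 3 values shown sit, while compound 3 shows a number. Compound 4 `CC(C)n1ncc2c(C(=O)Nc3cc(C(N)=O)ccc3F)cc(-c3cccs3)nc21` differs from compound 1 at one place: 5-carbamoyl-2-fluorophenyl in place of 2,6-difluorophenyl on an amide-type nitrogen. For the measured compounds named here, no step between two measured compounds is available, so the expected size of the step in this assay can only be guessed; none beyond the usual scatter is expected, in either direction. Compound 4 is therefore estimated at 200000 nM, between 100000 nM and 400000 nM, a step of a number no higher from compound 1 to compound 4 (the limit leaves the size open) expected to stay near the limit.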

Compound 4, half-maximal cytotoxic concentration: 25000 nM
Estimate against measurement, compound 4: 8.0-fold (0.90 log units) above; the measured number lies below the stated range.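

This position is not silent in this assay: 5-carbamoyl-2-fluorophenyl in place of 2,6-difluorophenyl on the amide-type nitrogen brings an at least 8.0-fold lower number from compound 1 to compound 4 (0.90 log units; beyond the scatter), and here a lower number stands for higher toxicity in this test. The true size of the step stays open because compound 1 stands at a limit, not a number: the limit of > 200000 nM in this assay, at which 2 of the 4 values shown sit.

The compounds shown do not separate the entering carbamoyl group from the loss of one fluorine. They also leave open whether a carboxylic acid, a nitrile or an amine in place of the carbamoyl group would give a similar number.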